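Propyl to methylamino on the pendant phenyl ring

This account rests on a few compounds, and the source may have more. Where it says the series, first, only, none or still open, it means among the compounds named here.

Going by the values given here, compound 2 `CCCc1ccc(-c2cc(C)cc(C(=O)Nc3nn[nH]n3)n2)cc1` stands lowest of the two numbers so far: in a functional assay on the whole organism for inhibition, with Rattus norvegicus as the target, at a dose of 0.3 mg/kg by the oral route (a lower number here means a weaker effect, a higher number a stronger effect of the compound at the dose given), compound 2 gives 19%, while compound 1 `CCCc1ccc(-c2cc(OC)cc(C(=O)Nc3nn[nH]n3)n2)cc1` gives 32%, the single known step being a number 13 percentage points lower from compound 1 to compound 2 (beyond the scatter). Compound 3 `CNc1ccc(-c2cc(C)cc(C(=O)Nc3nn[nH]n3)n2)cc1` differs from compound 2 by methylamino in place of propyl on an aromatic carbon. Among the compounds with values here, no measured step touches this part of the structure, so the one step known offers no guide, and no shift beyond the scatter is assumed in either direction. For compound 3 the expected value is 20%, range 5% to 40%. The step this estimate implies, a number 1 percentage points higher from compound 2 to compound 3 (within the scatter), is expected to stay within the scatter.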

Compound 3, a percentage reported as inhibition, in the whole organism at one dose (the size of the read-out at that dose, not a potency): 36%
Estimate against measurement, compound 3: 16 percentage points below; measured number inside the range.
By their numbers in this assay, from the lowest: compound 2; then compounds 1 and 3 (each within the scatter of the next).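

In this assay, methylamino in place of propyl on the aromatic carbon para to a large group gives a number 17 percentage points higher from compound 2 to compound 3 (beyond the scatter). This position therefore bears on the read-out at this dose, and propyl is not needed for the effect seen in this pair. No measured information on the compounds accounts for the step.

The compounds shown do not separate the entering nitrogen from the shorter chain, a distinction that an ethyl group, a primary amine or a dimethylamino group at this carbon would address. Also open, going by these compounds, is whether methylamino gives a similar step with methoxy in place of methyl on the shared core.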